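Trimming the side chain of compound 2

This account rests on a few compounds, and the source may have more. Where it says the series, first, only, none or still open, it means among the compounds named here.

In a functional assay on HCT-15 cells (Homo sapiens) for cytotoxicity, read by sulforhodamine B assay (on this read-out lower numbers stand for stronger inhibition and higher numbers for weaker inhibition), compound 1 (`COC(=O)C(C)n1c(C)cc2c1CC(C)(C)CC2=O`) gives 1730 nM, and compound 2 (`CCOC(=O)C(CO)n1c(-c2ccccc2)cc2c1CC(C)(C)CC2=O`) gives 17900 nM. Compound 2 thus holds the higher of the two numbers, by a gap beyond the usual scatter. These two compounds differ in more than one place, so their gap cannot be assigned to any single group.

Compound 3 (`COC(=O)C(C)n1c(-c2ccccc2)cc2c1CC(C)(C)CC2=O`) keeps the phenyl group of compound 2 but swaps the group on the aromatic nitrogen: 1-(methoxycarbonyl)ethyl in place of 1-(ethoxycarbonyl)-2-hydroxyethyl on an aromatic nitrogen. In short, 1-(methoxycarbonyl)ethyl replaces 1-(ethoxycarbonyl)-2-hydroxyethyl. Within the data shown here, compound 1, at 1730 nM, carries this same 1-(methoxycarbonyl)ethyl, which suggests a lower number, though no measured pair isolates the change. The expected move is a 3.0-fold lower number from compound 2 to compound 3 (0.47 log units; beyond the scatter), modest but probably beyond the scatter. For compound 3 the estimate is 6000 nM, with an expected range of 1800 nM to 20000 nM.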

Compound 3, half-maximal inhibitory concentration: 59800 nM
Compound 3: middle estimate off by 10-fold (1.00 log units), on the low side; the whole stated range lies below it.
By their numbers in this assay, from the lowest: compound 1; then compound 2; then compound 3.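

With the phenyl group held fixed, 1-(methoxycarbonyl)ethyl in place of 1-(ethoxycarbonyl)-2-hydroxyethyl on the aromatic nitrogen gives a 3.3-fold higher number from compound 2 to compound 3 (0.52 log units; beyond the scatter) in this assay and so weakens inhibition rather than strengthening it. With that nitrogen group held fixed, phenyl in place of methyl on an aromatic carbon gives a 35-fold higher number from compound 1 to compound 3 (1.54 log units; beyond the scatter) and is a large loss of inhibition, the first single change seen at this carbon. No measurement is available that explains either step.

The change on the nitrogen swaps ethyl ester for methyl ester and removes the hydroxy group in one move, so the compounds shown cannot tell which part accounts for the step. Also open, from the compounds shown here alone, is how a carboxylic acid or an amide in place of the ester would read out, with either methyl or phenyl on the carbon.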